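A Sulfonyl Swap After Three Measurements

The source may hold more compounds than are shown below. What is called first, only, known or untested is meant among the compounds shown, and "the series" means these compounds.

Compound 3 `Nc1nc2c(c(=O)n(CC3CC3)c(=O)n2CC2CC2)n1S(=O)(=O)c1ccc(C(F)(F)F)cc1` carries 4-(trifluoromethyl)phenyl on a sulfonyl sulfur bound to an aromatic nitrogen of the shared core. In an assay on isolated protein with dual specificity calcium/calmodulin-dependent 3',5'-cyclic nucleotide phosphodiesterase 1B (Bos taurus) as the target, tested at 100 uM (on this read-out lower numbers stand for less inhibition and higher numbers for more inhibition at the one concentration tested (going by the name of the read-out)), compound 3 gives 0%, level with compound 2 `Nc1nc2c(c(=O)n(CC3CC3)c(=O)n2CC2CC2)n1Cc1cccc2ccccc12`, which gives 0%; together they are the lowest of the three numbers. Compound 1 `COc1ccc(Cn2c(N)nc3c2c(=O)n(CC2CC2)c(=O)n3CC2CC2)cc1` stands well apart, giving 60%. Among the measured compounds shown here, the only step between measured compounds is a number 60 percentage points lower from compound 1 to compound 2 (beyond the scatter), a swap of the aromatic group on a chain carbon, not on a sulfonyl sulfur.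

Compound 4 `COc1ccc(OC)c(S(=O)(=O)n2c(N)nc3c2c(=O)n(CC2CC2)c(=O)n3CC2CC2)c1` differs from compound 3 by 2,5-dimethoxyphenyl in place of 4-(trifluoromethyl)phenyl on a sulfonyl sulfur. For the measured compounds named here, no measured step touches the group on the sulfonyl sulfur, so the step from compound 1 to compound 2 bears on it only loosely: it shows that changing the aromatic group on this side of the core can move the read-out a long way, there downward. Compound 3 already sits at the floor of the read-out, so little room for a further fall remains. Compound 4 is expected at 5%, within 0% to 25%. The estimated step of a number 5 percentage points higher from compound 3 to compound 4 (within the scatter) is expected to stay within the scatter.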

Compound 4, a percentage reported as inhibition, at one concentration (the size of the read-out at that concentration, not a potency): 31%
Beside the measured number, compound 4's estimate is 26 percentage points below it, outside the stated range (above it).
By their numbers in this assay, from the lowest: compounds 2 and 3 (each within the scatter of the next); then compound 4; then compound 1.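

The group on the sulfonyl sulfur clearly matters: in this assay, 2,5-dimethoxyphenyl in place of 4-(trifluoromethyl)phenyl gives a number 31 percentage points higher from compound 3 to compound 4 (beyond the scatter) on the same shared core. Among the compounds shown here, the sulfonyl compounds are therefore not all stuck at the bottom of the read-out, and a change at this position can raise the number, whereas the one earlier step, made on a chain carbon, lowered it. The two groups match in heavy-atom count and in their aromatic ring, differing in fluorine against oxygen and in hydrogen-bond acceptors, but no supporting data show which of these differences, if any, accounts for the rise.

As far as these compounds go, whether one methoxy group would be enough remains open, and so does the role of its place on the ring. A plain phenyl on the sulfonyl sulfur would show whether the number depends on adding the methoxy groups or on removing the trifluoromethyl group.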